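A few compounds are considered here, and "the series" means these few. Any claim that something is new, unique, unknown or untested is made for them only; others in the source may bear on it.

Working notes on the series. The shared core is carried unchanged by compound 1 `COc1ccccc1C(=O)Nc1cccc(-c2oc3cc(-c4ccc(F)cc4)ccc3c(=O)c2O)c1`, compound 2 `COc1cccc(C(=O)Nc2cccc(-c3oc4cc(-c5ccc(F)cc5)ccc4c(=O)c3O)c2)c1` and compound 3 `O=C(Nc1cccc(-c2oc3cc(-c4ccc(F)cc4)ccc3c(=O)c2O)c1)c1cccc(F)c1`; the three differ only in the aryl group on the amide carbonyl. In a functional assay on HeLa cells (Homo sapiens) for antiproliferative activity, read by CCK-8 assay, with a stated time of 72 h (on this read-out higher numbers stand for weaker inhibition and lower numbers for stronger inhibition), compound 1 gives 14100 nM, compound 2 gives 5650 nM and compound 3 gives 8780 nM. Going by the values given here, the only step that clears the scatter is a 2.5-fold lower number from compound 1 to compound 2 (0.40 log units; beyond the scatter). Compound 3 sits second highest of the three numbers, with a 1.6-fold lower number from compound 1 to compound 3 (0.21 log units; within the scatter) and a 1.6-fold higher number from compound 2 to compound 3 (0.19 log units; within the scatter) both within the scatter, so compound 3 cannot be ordered against either neighbour.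

Compound 4 `O=C(Nc1cccc(-c2oc3cc(-c4ccc(F)cc4)ccc3c(=O)c2O)c1)c1cc(F)cc(F)c1` is not yet measured in this assay. Relative to compound 3 the change is fluoro in place of hydrogen on an aromatic carbon, on an aromatic carbon meta to a fluoro group and meta to a large group. Among the compounds with values here, no measured step adds a second substituent to the amide aryl ring; the steps that exchange a single group on that ring stayed inside the scatter, apart from the modest move between compound 1 and compound 2. A second fluoro is therefore expected to give at most a small step in this assay, in no confident direction, and a 1.2-fold lower number from compound 3 to compound 4 (0.07 log units; within the scatter) is the estimated step. Compound 4 is expected at 7500 nM, with a range of 3000 nM to 20000 nM.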

Compound 4, half-maximal inhibitory concentration: 3380 nM
The estimate for compound 4 lay 2.2-fold (0.35 log units) above the measured number; the measured number falls inside the stated range.
By their numbers in this assay, from the lowest: compounds 4, 2, 3 and 1 (each within the scatter of the next, the first and the last beyond it).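

In this assay, going by these compounds alone, the change from 3-fluorophenyl to 3,5-difluorophenyl gives a 2.6-fold lower number from compound 3 to compound 4 (0.41 log units; beyond the scatter) and is a modest move, and it is the first step that adds a group to the amide aryl ring instead of exchanging one; this aromatic carbon, meta to a fluoro group and meta to a large group, therefore responds to a fluoro group in place of hydrogen by more than the scatter. Compared with the methoxy-bearing rings, the 3,5-difluorophenyl group gives a 4.2-fold lower number from compound 1 to compound 4 (0.62 log units; beyond the scatter) and so also clears the scatter, whereas a 1.7-fold lower number from compound 2 to compound 4 (0.22 log units; within the scatter) stays inside it, which leaves compound 4 and compound 2 unordered, so neither can be called the most active of the series. Nothing at hand offers a reason for the step seen with the second fluoro group.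

The compounds shown leave open whether the step belongs to fluoro itself or would also appear with chloro, methyl or trifluoromethyl on the same aromatic carbon. They also leave open whether it depends on the first fluoro group, and how an amine or a carboxylic acid on the amide aryl ring would read in this assay.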